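Changing the outer aryl group of a sulfonamide-acid inhibitor

The compounds below may be only part of what the source reports. "The series", "measured", "known", "first", "only" and "open" are said of these compounds alone.

Measured compounds:
compound 1, `CCCCCCCCS(=O)(=O)Nc1ccc(-c2ccc(Cl)cc2)cc1C(=O)O`: 9200 nM
compound 2, `CCCCCCCCS(=O)(=O)Nc1ccc(-c2ccc(OC)cc2)cc1C(=O)O`: 19500 nM

In an assay on mitochondria (strain BALB/c) for inhibition of glycerol-3-phosphate acyltransferase 1, mitochondrial (Mus musculus), read by scintillation counting, with a stated time of 10 min (a lower number here means a stronger inhibitor, a higher number a weaker inhibitor), compound 1 gives 9200 nM, and compound 2 gives 19500 nM. Compound 2 thus has the higher number of the two measured compounds, with a 2.1-fold higher number from compound 1 to compound 2 (0.33 log units; beyond the scatter). Compound 3, `CCCCCCCCS(=O)(=O)Nc1ccc(-c2ccccc2F)cc1C(=O)O`, is the next compound in this series; compared with compound 2 the change is 2-fluorophenyl in place of 4-methoxyphenyl on an aromatic carbon. Within the data shown here, only one measured step bears on this change, the one from compound 1 to compound 2, and it was modest: swapping one substituent on the outer ring for another moved the number only slightly beyond the scatter. Among the measured compounds shown here, a fluoro group in this arrangement has no measured precedent here, so the direction is uncertain, but a step of similar modest size is the most that the data suggest, probably a lowering, because compound 1 gives 9200 nM with a halogen on that ring. The expected step is a 1.8-fold lower number from compound 2 to compound 3 (0.25 log units; within the scatter). Compound 3 is therefore estimated at 11000 nM, with a range from 4000 nM to 30000 nM.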

Compound 3, half-maximal inhibitory concentration: 34600 nM
Compound 3: the middle estimate sits 3.1-fold (0.50 log units) below what was measured; measured number above the stated range.
By their numbers in this assay, from the lowest: compound 1; then compounds 2 and 3 (each within the scatter of the next).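

With 2-fluorophenyl in place of 4-methoxyphenyl, the result is a 1.8-fold higher number from compound 2 to compound 3 (0.25 log units; within the scatter) in this assay, so this swap on the outer ring does not separate the two compounds. With 2-fluorophenyl in place of 4-chlorophenyl, the result is a 3.8-fold higher number from compound 1 to compound 3 (0.58 log units; beyond the scatter), so a halogen on the outer ring is not enough to match compound 1, and the 4-chlorophenyl group remains the only one of the three set apart from the others. No measurement shown here accounts for these differences.

Because compound 1 and compound 3 differ in both the halogen and its place on the ring, the compounds shown cannot say which of the two matters. On these data alone, a 4-fluorophenyl or 2-chlorophenyl group would separate these two changes, and an outer ring bearing an amine remains open as well.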